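The compounds below may be only part of what the source reports. "The series", "measured", "known", "first", "only" and "open" are said of these compounds alone.

Compound 1 `O=C(O)c1cc(-c2c[nH]cn2)ccc1O`: 100 mg/kg
Compound 2 `O=C(O)c1cc(-c2ccccn2)ccc1O`: 200 mg/kg
Compound 3 `CCCCOC(=O)Oc1ccc(-n2cccc2)cc1C(=O)O`: 52 mg/kg

Of the compounds shown here, three have been tested in a functional assay on the whole organism for inhibition, with Rattus norvegicus as the target, read by paw edema; a higher number here means that more compound is needed for the effect, a lower number that less compound is needed. Compound 1 gives 100 mg/kg, and its number lies within the usual scatter of both compound 3 at 52 mg/kg and compound 2 at 200 mg/kg, so nothing separates these three beyond the noise of the measurement. Compound 4 `O=C(O)c1cc(-c2ccno2)ccc1O` has not been measured. It differs from compound 1 in one place: 1,2-oxazol-5-yl in place of 1H-imidazol-4-yl on an aromatic carbon. For the measured compounds named here, no step between measured compounds isolates this change, so only an expectation is possible. The author expects a step from compound 1 to compound 4 of a 1.2-fold higher number from compound 1 to compound 4 (0.08 log units; within the scatter), a change small enough to stay within the scatter. Compound 4 is therefore estimated at 120 mg/kg in this assay, with a range from 50 mg/kg to 300 mg/kg.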

Compound 4, dose for half-maximal effect: 110 mg/kg
Compound 4: the middle estimate sits 1.1-fold (0.04 log units) above what was measured; the measured number falls inside the stated range.
By their numbers in this assay, from the lowest: compounds 3, 1, 4 and 2 (each within the scatter of the next, the first and the last beyond it).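

In this assay, for the compounds shown here, the step of a 1.1-fold higher number from compound 1 to compound 4 (0.04 log units; within the scatter) is the first single-place comparison at this position, meta to the carboxy group and para to the hydroxy group. It shows that 1,2-oxazol-5-yl, with 0 hydrogen-bond donors, can replace 1H-imidazol-4-yl, with 1 hydrogen-bond donor, without the number moving beyond the scatter. No measured evidence bears on this result.

The compounds shown leave open what a phenyl group would do at this position. They also leave open whether a methyl group on the 1,2-oxazol-5-yl ring would move the number beyond the scatter.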